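Replacing the anilino group with methylsulfanyl on a purine core

The source may hold more compounds than are shown below. What is called first, only, known or untested is meant among the compounds shown, and "the series" means these compounds.

Compound 2 `c1ccc(Cn2cnc3c(Nc4ccccc4)ncnc32)cc1` gives the lower number of the two measured compounds: in a functional assay on the whole organism for inhibition, with Rattus norvegicus as the target, in the maximal electroshock model, at a dose of 25 mg/kg by the intraperitoneal route (a higher number here means more inhibition at the dose given (going by the name of the read-out), a lower number less inhibition), compound 2 gives 0%, while compound 1 `c1ccc(Cn2cnc3c(N4CCC4)ncnc32)cc1` gives 17%. For the measured compounds named here, the one measured step, a number 17 percentage points lower from compound 1 to compound 2 (beyond the scatter), shows that changing this group can move the number. Compound 3 `CSc1ncnc2c1ncn2Cc1ccccc1` differs from compound 2 by methylsulfanyl in place of anilino on an aromatic carbon. Going by the values given here, no measured step covers this exact change, so the expectation is uncertain. Compound 3 is expected to give 12%, within 0% to 35%. That means an expected step of a number 12 percentage points higher from compound 2 to compound 3 (beyond the scatter), a small rise that may not exceed the scatter.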

Compound 3, a percentage reported as inhibition, in the whole organism at one dose (the size of the read-out at that dose, not a potency): 30%
Beside the measured number, compound 3's estimate is 18 percentage points below it; measured number inside the range.
By their numbers in this assay, from the lowest: compound 2; then compound 1; then compound 3.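

Methylsulfanyl on this aromatic carbon gives a number 30 percentage points higher from compound 2 to compound 3 (beyond the scatter), and a number 13 percentage points higher from compound 1 to compound 3 (beyond the scatter). For the compounds shown here, the one earlier step showed only a fall at this place, whereas this change shows that a group here can also raise the number, and methylsulfanyl, the only one of the three groups without a ring, gives the highest value so far.

Nothing available explains this rise. Still open, on these data alone, is whether the sulfur or the lack of a ring matters, and a methoxy group or a longer butylsulfanyl chain here would bear on that question.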